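Trimming the Tail Beyond the Amide Nitrogen

The source may hold more compounds than are shown below. What is called first, only, known or untested is meant among the compounds shown, and "the series" means these compounds.

Compound 3 `O=C(CCc1ccc(Cl)cc1)C(=O)NCc1ccccc1` is the anchor here. In an assay on HEK-293T cells for inhibition of phospholipase A and acyltransferase 5 (Homo sapiens), with stated times of 30 min and 20 min (a lower number here means a stronger inhibitor, a higher number a weaker inhibitor), compound 3 gives 251 nM, the highest of the two numbers recorded. Its nearest neighbour is compound 1 `O=C(CCc1ccc(Cl)cc1)C(=O)NCCCCc1ccccc1`, which in this assay gives 200 nM; the gap between compound 1 and compound 3 lies within the scatter, so the two cannot be ranked. Compound 2 `O=C(CCc1ccccc1)CC(=O)NCc1ccccc1` in this assay gives > 10000 nM, which is a limit of the assay rather than a number (the limit of > 10000 nM in this assay, at which 1 of the 3 values shown sits). Among the compounds with values here, compound 4 `CCNC(=O)C(=O)CCc1ccc(Cl)cc1` has not been measured yet. methyl in place of phenyl on a saturated chain carbon bound to an amide-type nitrogen No measured pair tests this change, so no measured step guides the guess. Compound 4 is expected to be a weaker inhibitor, with the expected step of a 6.0-fold higher number from compound 3 to compound 4 (0.78 log units; beyond the scatter) lying beyond the scatter. The estimate for compound 4 in this assay is 1500 nM, within 400 nM and 8000 nM.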

Compound 4, half-maximal inhibitory concentration: 1000 nM
Estimate against measurement, compound 4: 1.5-fold (0.18 log units) above; measured number inside the range.
By their numbers in this assay, from the lowest: compounds 1 and 3 (each within the scatter of the next); then compound 4. At a limit, above all of these: compound 2.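

The phenyl ring on the tail now shows its worth: a 4.0-fold higher number from compound 3 to compound 4 (0.60 log units; beyond the scatter) and a 5.0-fold higher number from compound 1 to compound 4 (0.70 log units; beyond the scatter) both mark a modest loss in this assay when the tail is cut back to ethyl. Compound 4 at 1000 nM still inhibits without that ring, so the ring helps but is not required. Nothing measured here says why the number rises. Still open, on these data alone, is whether a cyclohexyl ring at the end of the tail would serve as well as phenyl, and whether an amine or a carboxylic acid there would be tolerated.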